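A few compounds are considered here, and "the series" means these few. Any claim that something is new, unique, unknown or untested is made for them only; others in the source may bear on it.

Compound 1 `O=S(=O)(Nc1cc(-c2cnc3[nH]ncc3c2)cnc1Cl)c1ccccc1` gives 7610 nM in a functional assay on NCI-H460 cells (Homo sapiens) for inhibition, read by sulforhodamine B assay, with a stated time of 72 h; a higher number here means a weaker inhibitor of growth, a lower number a stronger inhibitor of growth. Compound 2 `O=S(=O)(Nc1cc(-c2cnc3[nH]nc(-c4ccccc4)c3c2)cnc1Cl)c1ccccc1`, which carries a phenyl on the five-membered ring of the shared core, gives 8650 nM in this assay; the step of a 1.1-fold higher number from compound 1 to compound 2 (0.06 log units; within the scatter) is small. Compound 3 `O=S(=O)(Nc1cc(-c2cnc3[nH]cc(-c4ccccc4)c3c2)cnc1Cl)c1ccccc1` gives only a limit of this assay, > 10000 nM. Among the numbers shown, compound 2 stands highest of the two, with compound 1 nearest and within the scatter, while the third value is a limit (the limit of > 10000 nM in this assay, at which 1 of the 3 values shown sits).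

Compound 4 `O=S(=O)(Nc1cc(-c2cnc3[nH]nc(-c4ccncc4)c3c2)cnc1Cl)c1ccccc1` is the next step: pyridin-4-yl in place of phenyl on an aromatic carbon. Among the compounds with values here, the only measured step that touches this position is the one from compound 1 to compound 2, in which the phenyl itself was added and which stayed within the scatter. The exchange of phenyl for pyridin-4-yl is a smaller change than that addition, so no step beyond the scatter is expected in this assay, in either direction. Compound 4 is therefore expected to give about 8500 nM, between 4000 nM and 16000 nM, which means an estimated step of a 1.0-fold lower number from compound 2 to compound 4 (0.01 log units; within the scatter).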

Compound 4, concentration for 50% growth inhibition: 2500 nM
Compound 4: middle estimate off by 3.4-fold (0.53 log units), on the high side, and the stated range ends above it.
By their numbers in this assay, from the lowest: compound 4; then compounds 1 and 2 (each within the scatter of the next). At a limit, above all of these: compound 3.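

In this assay, this position proves able to respond after all: adding phenyl to the core had stayed within the scatter, whereas exchanging that phenyl for pyridin-4-yl gives a 3.5-fold lower number from compound 2 to compound 4 (0.54 log units; beyond the scatter). Measured against the bare core, pyridin-4-yl in place of hydrogen gives a 3.0-fold lower number from compound 1 to compound 4 (0.48 log units; beyond the scatter), so among these compounds, the six-membered aromatic ring on this carbon goes with a step beyond the scatter only when it holds a ring nitrogen. Nothing measured here accounts for this difference between the two rings.

The compounds shown leave open whether the place of the ring nitrogen matters, as a comparison with pyridin-3-yl could show. They also leave open how a saturated amine such as piperidin-4-yl, or a phenyl bearing a carboxylic acid, would behave on this carbon.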